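This account rests on a few compounds, and the source may have more. Where it says the series, first, only, none or still open, it means among the compounds named here.

In a functional assay on SK-OV-3 cells (Homo sapiens) for antiproliferative activity, read by MTT assay, with a stated time of 24 h (a lower number here means a stronger inhibitor, a higher number a weaker inhibitor), compound 3 (`COc1ccc(C(=O)/C=C/c2ccccc2)c2c1C=CC(C)(C)O2`) gives > 10000 nM as a limit of the assay, not a number. Compound 1 (`COc1ccc(C(=O)/C=C/c2cccc(F)c2)c2c1C=CC(C)(C)O2`) gives > 10000 nM and that too is a limit. Compound 2 (`COc1ccc(C(=O)/C=C/c2ccc(N(C)C)cc2)c2c1C=CC(C)(C)O2`) alone gives a number, 2750 nM in the same read-out. For the measured compounds named here, compound 4 (`COc1ccc(C(=O)/C=C/c2ccco2)c2c1C=CC(C)(C)O2`) brings furan-2-yl in place of phenyl on a double-bonded chain carbon bound to a double-bonded chain carbon and no measured step swaps that ring. The nearest steps touch only substituents on the phenyl: an at least 3.6-fold higher number from compound 2 to compound 3 (0.56 log units; beyond the scatter) on losing dimethylamino, and a step that the two limits leave unreadable from compound 1 to compound 3 on losing fluoro. Compound 4 lacks the dimethylamino of compound 2 at 2750 nM in this assay and so no step beyond the scatter is expected. The estimated step is an at least 1.1-fold lower number from compound 3 to compound 4 (0.04 log units; that floor lies within the scatter) and no more. Compound 4 is expected at 9000 nM within an estimated range of 3000 nM to 25000 nM and may stay at the limit.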

Compound 4, half-maximal inhibitory concentration: > 10000 nM
Compound 4: no number, only a limit; the forecaster's own chance of this, stated with the estimate: 55%; at least 1.1-fold (0.04 log units) between middle value and limit.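

In this assay, for the compounds shown here, a change of the ring itself at this position, furan-2-yl in place of phenyl, gives no number, so compound 2 remains the only compound with one. Furan-2-yl in place of 4-(dimethylamino)phenyl gives an at least 3.6-fold higher number from compound 2 to compound 4 (0.56 log units; beyond the scatter). The steps to compound 4 from compound 1 and compound 3 cannot be read because both ends of each are limits: the limit of > 10000 nM in this assay, at which 3 of the 4 values shown sit.

Open, on these data alone, is whether the number of compound 2 depends on dimethylamino specifically. A primary amine or a methoxy group on the phenyl, or dimethylamino on the furan-2-yl, would address this.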